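Nitro on the benzyl ring in two isomeric anilines

A few compounds are considered here, and "the series" means these few. Any claim that something is new, unique, unknown or untested is made for them only; others in the source may bear on it.

Compound 1 `c1ccc(COc2ccccc2Nc2ncnc3cc4c(cc23)OCCOCCOCCO4)cc1` is measured in a functional assay on SH-SY5Y cells (Homo sapiens) for antiproliferative activity, read by MTT assay, with a stated time of 72 h (on this read-out lower numbers stand for stronger inhibition and higher numbers for weaker inhibition), at 98400 nM. Compound 2 `O=[N+]([O-])c1ccc(COc2ccccc2Nc2ncnc3cc4c(cc23)OCCOCCOCCO4)cc1` gives 75500 nM in this assay. Between these two stands a single change, (nitro in place of hydrogen on an aromatic carbon), and it made the step of a 1.3-fold lower number from compound 1 to compound 2 (0.12 log units; within the scatter). Compound 3 `c1ccc(COc2cccc(Nc3ncnc4cc5c(cc34)OCCOCCOCCO5)c2)cc1` has the same atoms as compound 1 joined differently; how the two cores differ is not broken down here. In this assay compound 3 gives 22800 nM, the lowest number of the three, and its gaps to compound 1 and to compound 2 both lie beyond the scatter, so compound 3 is the strongest inhibitor measured so far. Compound 4 `O=[N+]([O-])c1ccc(COc2cccc(Nc3ncnc4cc5c(cc34)OCCOCCOCCO5)c2)cc1` is not yet measured; it relates to compound 3 by nitro in place of hydrogen on an aromatic carbon. The place of this change reads word for word as in the earlier pair, so it is the same change, occurring twice among the compounds shown. For the measured compounds named here, the expected step is a 1.3-fold lower number from compound 3 to compound 4 (0.10 log units; within the scatter), set beside a 1.3-fold lower number from compound 1 to compound 2 (0.12 log units; within the scatter), the one earlier instance, which lay within the scatter. For compound 4 the estimate in this assay is 18000 nM, expected between 7000 nM and 45000 nM.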

Compound 4, half-maximal inhibitory concentration: > 100000 nM
Compound 4 was reported as a limit; the forecaster's own chance of this, stated with the estimate: 5%; middle value at least 5.5-fold (0.74 log units) from the limit.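

In this assay compound 4 is reported only as a limit of the assay, > 100000 nM, and not as a number. Nitro in place of hydrogen on the benzyl ring does not carry over unchanged from one core to the other: an at least 4.3-fold higher number from compound 3 to compound 4 (0.64 log units; beyond the scatter) stands against a step within the scatter on the other core, and the two steps differ: the same change on two cores in this assay, a 1.3-fold lower number (0.12 log units; within the scatter) from compound 1 to compound 2 and an at least 4.3-fold higher number (0.64 log units; beyond the scatter) from compound 3 to compound 4, at least 5.7-fold (0.75 log units) apart, beyond the scatter of two such steps. This shows that the outcome of this change depends on the core in this series, but with a single pair on each core it does not show why the two cores part, nor how far the true value of compound 4 lies from the limit.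

Open, from the compounds shown here alone, is whether the split between the cores belongs to nitro alone or would also appear with an amine, a nitrile or a carboxylic acid in its place on the benzyl ring. Also open, going by these compounds, is how either core would respond to a longer chain in place of the benzyl link.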